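The source may hold more compounds than are shown below. What is called first, only, known or untested is meant among the compounds shown, and "the series" means these compounds.

Compound 1 `C=C1C(=O)[C@]23C[C@@]1(O)CC[C@H]2c1ccc(O)c(C)c1[C@@H]3Cn1cc(-c2ccc(F)cc2)nn1` and compound 2 `C=C1C(=O)[C@]23C[C@@]1(O)CC[C@H]2c1ccc(O)c(C)c1[C@@H]3Cn1cc(-c2ccc(C(F)(F)F)cc2)nn1` share one core and differ only at the outer end of the molecule. In a functional assay on A549 cells (Homo sapiens) for cytotoxicity, read by MTT assay, with a stated time of 4 days (on this read-out lower numbers stand for stronger inhibition and higher numbers for weaker inhibition), compound 1 gives 940 nM, and compound 2 gives 1110 nM. The change between them is trifluoromethyl in place of fluoro on an aromatic carbon, and it made a 1.2-fold higher number from compound 1 to compound 2 (0.07 log units; within the scatter), so the two values cannot be told apart here.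

Compound 3 `C=C1C[C@]23C[C@@]1(O)CC[C@@H]2c1cccc(C)c1[C@@H]3Cn1cc(-c2ccc(F)cc2)nn1` is built on a different core. How the two cores differ is not broken down here. In this assay compound 3 reaches only (the limit of > 20000 nM in this assay, at which 1 of the 3 values shown sits), which is a limit of the measurement and not a number; its value stands as > 20000 nM.

Compound 4 `C=C1C[C@]23C[C@@]1(O)CC[C@@H]2c1cccc(C)c1[C@@H]3Cn1cc(-c2ccc(C(F)(F)F)cc2)nn1` has not yet been measured. It stands to compound 3 as compound 2 stands to compound 1: the change is trifluoromethyl in place of fluoro on an aromatic carbon, the same change as before, at the same place.

On the first core this change left the readout within the scatter. Compound 4 is therefore expected to sit near compound 3, that is, beyond the limit of this assay as well, resting on the fact that compound 3 gives > 20000 nM and that the same change made a 1.2-fold higher number from compound 1 to compound 2 (0.07 log units; within the scatter). The expected step is a step that the limit leaves unreadable from compound 3 to compound 4, and the estimate for compound 4 is 40000 nM, within 15000 nM to 150000 nM.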

Compound 4, half-maximal inhibitory concentration: > 20000 nM
Compound 4: a limit, no number; the forecaster's own chance of this, stated with the estimate: 85%; the middle value lies beyond the limit too.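

In this assay compound 3 gives > 20000 nM, which is a limit and not a number. For the compounds shown here, compound 4 gives > 20000 nM, also a limit, so no step between these two compounds can be read. The compounds shown leave open whether trifluoromethyl in place of fluoro changes anything on the core of compound 3, and which of the differences between that core and the core of compound 1 matters.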